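The source may report more compounds than this note shows. Statements on the series, on what has been measured and on what is new or still open speak of the compounds shown alone.

Measured so far in a physicochemical assay for solubility, read by HPLC, in phosphate buffer, measured as kinetic solubility, with a stated time of 1 h, at pH 7.4, tested at 250 uM; a lower number here means a less soluble compound, a higher number a more soluble compound

- Compound 1 `O=C(NCCCCc1ccccc1)n1cc(-c2ccc(F)cc2)oc1=O` gives < 1000 nM
- Compound 2 `COc1cc(-c2cn(C(=O)NCCCCc3ccccc3)c(=O)o2)ccc1F` gives < 1000 nM
- Compound 3 `O=C(NCCCCc1ccccc1)n1cc(-c2cnccn2)oc1=O` gives < 1000 nM

Compound 2 stands at < 1000 nM, which is a limit of the assay and not a number. The other two compounds sit at the same limit (the limit of < 1000 nM in this assay, at which 3 of the 3 values shown sit), so the series has no measured number yet.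

Compound 4 `CN1CCC(c2cc(-c3cn(C(=O)NCCCCc4ccccc4)c(=O)o3)ccc2F)CC1` carries 1-methylpiperidin-4-yl in place of the methoxy of compound 2, on an aromatic carbon ortho to a fluoro group (1-methylpiperidin-4-yl in place of methoxy on an aromatic carbon). Among the measured compounds shown here, three measured steps bear on this change, since each alters the same aromatic group or replaces it: a step that the two limits leave unreadable from compound 1 to compound 2, a step that the two limits leave unreadable from compound 1 to compound 3 and a step that the two limits leave unreadable from compound 2 to compound 3. For the measured compounds named here, none has a readable size, and none brought in a non-aromatic ring, so they set no size for this step. A rise in this assay is therefore expected on judgement alone, and another limit remains quite possible. The expected change is an at least 10-fold higher number from compound 2 to compound 4 (1.00 log units; beyond the scatter). For compound 4 the estimate is 10000 nM, with an expected range of 1000 nM to 150000 nM.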

Compound 4, solubility: 30000 nM
The estimate for compound 4 lay 3.0-fold (0.48 log units) below the measured number; the measured number falls inside the stated range.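

In this assay compound 4 gives 30000 nM, the only measured number among the compounds shown. On this aromatic carbon, ortho to a fluoro group, 1-methylpiperidin-4-yl in place of methoxy gives an at least 30-fold higher number from compound 2 to compound 4 (1.47 log units; beyond the scatter), and the same group in place of hydrogen gives an at least 30-fold higher number from compound 1 to compound 4 (1.47 log units; beyond the scatter); both steps start from a limit, so their true sizes could be larger. The steps among compound 1, compound 2 and compound 3 cannot be read, and these three compounds remain at a limit of the assay: the limit of < 1000 nM in this assay, at which 3 of the 4 values shown sit.

On these data alone, whether the rise goes with the amine nitrogen or with the non-aromatic ring stays open: a cyclohexyl group or an open-chain amine such as dimethylaminomethyl at this position would separate the two. As far as these compounds go, it also stays open whether 1-methylpiperidin-4-yl on another carbon of this aromatic ring would give a step of similar size.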